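A few compounds are considered here, and "the series" means these few. Any claim that something is new, unique, unknown or untested is made for them only; others in the source may bear on it.

In an ADME assay on HEK293 cells (Homo sapiens) for cytotoxicity, read by ATP content, with a stated time of 6 h (a lower number here means that less compound is tolerated, a higher number that more compound is tolerated), compound 3 (`CCC(O)CNc1nc(N)nc2ccn(Cc3ccccn3)c12`) reads > 24000 nM and this is a limit of the assay, not a number. Compound 1 (`CCCCNc1nc(N)nc2ccn(CC(=O)NC)c12`) gives > 24000 nM as a limit too. Compound 2 (`CCCCNc1nc(N)nc2ccn(Cc3cccnc3)c12`) also gives > 24000 nM as a limit. Compound 3 thus stands with the other two at the limit of > 24000 nM in this assay, at which 3 of the 3 values shown sit, and no number separates them. Compound 4 (`Cc1cnc(CNc2nc(N)nc3ccn(Cc4ccccn4)c23)o1`) carries 5-methyl-1,3-oxazol-2-yl in place of 1-hydroxypropyl on a saturated chain carbon bound to a nitrogen on an aromatic ring, and the count reads 5-methyl-1,3-oxazol-2-yl in place of 1-hydroxypropyl on a saturated chain carbon bound to a nitrogen on an aromatic ring for this change. Among the measured compounds shown here, the only measured step, a step that the two limits leave unreadable from compound 1 to compound 2 in this assay, lies at a different place and offers no size to carry over. No shift beyond the usual scatter is therefore expected, and the estimated change is a step that the limit leaves unreadable from compound 3 to compound 4 in this reading. The expectation rests on compound 3 at > 24000 nM as a limit, and compound 4 will most likely be reported as a limit as well. For compound 4 the estimated value is 30000 nM with an expected range from 12000 nM to 60000 nM in the same assay.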

Compound 4, half-maximal cytotoxic concentration: > 24000 nM
Compound 4: only a limit was reported (the forecaster's own chance of this, stated with the estimate: 85%); the middle value lies beyond the limit too.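

No step can be read from compound 3 to compound 4, since this assay gives only limits for both compounds: the limit of > 24000 nM in this assay, at which 4 of the 4 values shown sit. The compounds shown leave open how far each lies from that limit and whether any real difference separates them.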